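The source may hold more compounds than are shown below. What is called first, only, known or untested is meant among the compounds shown, and "the series" means these compounds.

Measured compounds:
compound 1 `O=C(O)[C@@H]1CCCN1C(=O)CN(c1nc(Cl)nc2[nH]cnc12)C1CC1` — 34.9%
compound 2 `C[C@H](NC(=O)CN(c1nc(Cl)nc2[nH]cnc12)C1CC1)C(=O)O` — 44.6%

In a functional assay on the whole organism (Tail, strain ICR) with Mus musculus as the target, in the tail flick test, with a stated time of 60 min, at a dose of 25 umol/kg by the oral route (a higher number here means a stronger effect of the compound at the dose given, a lower number a weaker effect), compound 2 and compound 1 give numbers that lie within the scatter of each other; the step of a number 9.7 percentage points higher from compound 1 to compound 2 (within the scatter) is the only one measured. Compound 3 `NCCCC[C@H](NC(=O)CN(c1nc(Cl)nc2[nH]cnc12)C1CC1)C(=O)O` differs from compound 2 by 3-aminopropyl in place of hydrogen on a saturated chain carbon, two bonds along the chain from an amide-type nitrogen and a carbonyl carbon. For the measured compounds named here, no measured step touches this part of the chain; the one step known changes the group on the carbonyl carbon and stayed within the scatter. No basis for a shift beyond the scatter is seen. Compound 3 is expected at 42%, range 24% to 60%, a step of a number 2.6 percentage points lower from compound 2 to compound 3 (within the scatter) being the estimate.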

Compound 3, a percentage reported as activity, at one dose (the size of the read-out at that dose, not a potency): 53.8%
Beside the measured number, compound 3's estimate is 11.8 percentage points below it; low and high end bracket the measured number.
By their numbers in this assay, from the lowest: compounds 1, 2 and 3 (each within the scatter of the next, the first and the last beyond it).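

In this assay the saturated chain carbon two bonds along the chain from an amide-type nitrogen and a carbonyl carbon accepts 3-aminopropyl in place of hydrogen, with a number 9.2 percentage points higher from compound 2 to compound 3 (within the scatter). For the compounds shown here, this is the first reading at this position, and a chain carrying an amine leaves the read-out within the scatter. No measurement offered here bears on why the step has this size.

Open, as far as these compounds go, is whether a plain butyl chain without the amine, or a chain ending in a carboxylic acid, would read the same at this position. Also open, from the compounds shown here alone, is how a longer chain bearing a guanidine would compare.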